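The compounds below may be only part of what the source reports. "The series", "measured", "known", "first", "only" and "open" are said of these compounds alone.

Of the compounds shown here, two with the same amide core have been measured. Compound 1 `CC(C)(C)c1ccc(C2CC2C(=O)Nc2ccc3c(c2)OCCO3)cc1` carries a cyclopropane between the tert-butylphenyl group and the amide, and in a functional assay on CHO cells for inhibition of transient receptor potential cation channel subfamily V member 1 (Homo sapiens) (on this read-out lower numbers stand for stronger inhibition and higher numbers for weaker inhibition), compound 1 gives 1800 nM. Compound 2 `CC(C)(C)c1ccc(/C(=C/C(=O)Nc2ccc3c(c2)OCCO3)c2cccnc2)cc1` replaces that ring with a double-bonded chain bearing a pyridin-3-yl group; in this assay compound 2 gives 78 nM, the lowest number of the two and well beyond the scatter from compound 1.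

Compound 3 `CC(C)(C)c1ccc(/C(=C/C(=O)Nc2ccc3c(c2)OCCO3)CCC(=O)O)cc1` is the next variation. Compared with compound 2 it has 2-carboxyethyl in place of pyridin-3-yl on a double-bonded chain carbon bound to an aromatic carbon and a double-bonded chain carbon. For the measured compounds named here, no pair of measured compounds with this exact change exists, so there is no measured step to lean on; only the two values of compound 1 and compound 2 are available, and they concern a different part of the molecule.

Because compound 2 gives 78 nM, the starting point is a strong one, and the expectation is that the step of a 7.7-fold higher number from compound 2 to compound 3 (0.89 log units; beyond the scatter) leads to a higher number, weaker inhibition, by a clear margin. The estimate for compound 3 in this assay is 600 nM, with a plausible range from 120 nM to 3000 nM.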

Compound 3, half-maximal inhibitory concentration: > 4000 nM
Compound 3 ended at the assay's limit (the forecaster's own chance of this, stated with the estimate: 10%); middle value at least 6.6-fold (0.82 log units) away from the limit.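

For the compounds shown here, this is the first measured step at the position on a double-bonded chain carbon bound to an aromatic carbon and a double-bonded chain carbon, and it shows that the group placed there has a strong bearing on the result. In this assay, 2-carboxyethyl in place of pyridin-3-yl gives an at least 51-fold higher number from compound 2 to compound 3 (1.70 log units; beyond the scatter), a large change that lies well beyond the scatter, so this open chain does not stand in for the aromatic ring at this position. Compound 3 stands at a limit of the assay, and the step therefore gives only a lower bound on the true change: the limit of > 4000 nM in this assay, at which 1 of the 3 values shown sits.

The swap removes an aromatic ring and brings in a chain ending in a carboxylic acid in a single move, so the compounds shown cannot tell whether the loss of the ring, the presence of the acid or both go with the weaker inhibition. A plain propyl chain or the methyl ester of the 2-carboxyethyl group at this position would separate these two parts of the change, and a phenyl ring would show how much the ring nitrogen of pyridin-3-yl counts.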